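This account rests on a few compounds, and the source may have more. Where it says the series, first, only, none or still open, it means among the compounds named here.

Working notes on the series in a functional assay on A-375 cells (Homo sapiens) for cytotoxicity, read by MTT assay; a lower number here means a stronger inhibitor, a higher number a weaker inhibitor. Compound 1 `COc1ccc(/C=C/C(=O)c2ccc(OC)c3c2OC(C)(C)C=C3)cc1O` gives 800 nM. Compound 3 `COc1ccc(/C=C/C(=O)c2ccc(OC)c3c2OC(C)(C)C=C3)cc1OC(=O)c1ccco1` gives 680 nM, and a 1.2-fold lower number from compound 1 to compound 3 (0.07 log units; within the scatter) leaves the two level, so compound 3 stands with compound 1 among the measured numbers. Compound 2 `C=CCOc1cc(/C=C/C(=O)c2ccc(OC)c3c2OC(C)(C)C=C3)ccc1OC` reads > 10000 nM, which is a limit of the assay. Allyl on the same oxygen gives an at least 12-fold higher number from compound 1 to compound 2 (1.09 log units; beyond the scatter), and the exchange for (furan-2-yl)carbonyl gives an at least 14-fold lower number from compound 2 to compound 3 (1.16 log units; beyond the scatter).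

Compound 4 `COc1ccc(/C=C/C(=O)c2ccc(OC)c3c2OC(C)(C)C=C3)cc1OS(=O)(=O)c1ccc(C)cc1` differs from compound 3 as follows: (4-methylphenyl)sulfonyl in place of (furan-2-yl)carbonyl on an oxygen on an aromatic ring. It carries (4-methylphenyl)sulfonyl in place of (furan-2-yl)carbonyl on an oxygen on an aromatic ring. Among the measured compounds shown here, no sulfonyl compound has been measured yet, so only the steps at this oxygen bear on the change, and they point both ways. Compound 3 keeps the level of compound 1 with a 1.2-fold lower number from compound 1 to compound 3 (0.07 log units; within the scatter), while compound 2 loses it with an at least 12-fold higher number from compound 1 to compound 2 (1.09 log units; beyond the scatter). A moderate move to a higher number is therefore expected, short of the loss seen for compound 2. The expected step is a 2.2-fold higher number from compound 3 to compound 4 (0.34 log units; beyond the scatter). For compound 4 the estimated value is 1500 nM, with an estimated range of 400 nM to 7000 nM.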

Compound 4, half-maximal inhibitory concentration: 2400 nM
The estimate for compound 4 lay 1.6-fold (0.20 log units) below the measured number, within the range that was stated.
By their numbers in this assay, from the lowest: compounds 3 and 1 (each within the scatter of the next); then compound 4. At a limit, above all of these: compound 2.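

Among the compounds shown here, on this oxygen, (4-methylphenyl)sulfonyl gives an outcome the earlier compounds did not show: a modest loss, with a 3.0-fold higher number from compound 1 to compound 4 (0.48 log units; beyond the scatter) and a 3.5-fold higher number from compound 3 to compound 4 (0.55 log units; beyond the scatter) as its two steps, so that replacing the hydrogen here is neither level, as in compound 3, nor a fall to a limit, as in compound 2. The value of compound 2 is a limit and not a number: the limit of > 10000 nM in this assay, at which 1 of the 4 values shown sits. The step of an at least 4.1-fold lower number from compound 2 to compound 4 (0.61 log units; beyond the scatter) is therefore a bound only, and it shows that a large group on this oxygen can still leave a measurable number where allyl does not.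

The compounds shown do not separate the sulfonyl link from the ring it carries, as (4-methylphenyl)carbonyl or methylsulfonyl on this oxygen could. On these data alone, how a chain ending in an amine or a carboxylic acid would read here also stays open.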